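A few compounds are considered here, and "the series" means these few. Any claim that something is new, unique, unknown or untested is made for them only; others in the source may bear on it.

Compound 1 `O=C1O[C@H]([C@@H](O)Cn2cc(-c3ccc(Br)cc3)nn2)C(OCc2ccccc2)=C1OCc1ccccc1` carries the only numerical result in the set: in a functional assay on A549 cells (Homo sapiens) for antiproliferative activity, read by MTT assay, with a stated time of 72 h (a lower number here means a stronger inhibitor, a higher number a weaker inhibitor), compound 1 gives 750 nM. Compound 2 `CC(C)(C)OC(=O)N1CCN(C(=S)SCc2cn(C[C@H](O)[C@H]3OC(=O)C(OCc4ccccc4)=C3OCc3ccccc3)nn2)CC1` returns only a limit, as in this assay compound 2 gives > 100000 nM, which is the limit of > 100000 nM in this assay, at which 1 of the 2 values shown sits. Among the measured compounds shown here, no measured pair differs in one place, so no step size is known from the data. Compound 3 `Cc1ccc(-c2cn(C[C@H](O)[C@H]3OC(=O)C(OCc4ccccc4)=C3OCc3ccccc3)nn2)cc1` differs from compound 1 by methyl in place of bromo on an aromatic carbon. The expected step of a 1.5-fold higher number from compound 1 to compound 3 (0.17 log units; within the scatter) is estimated to be small, at most a slight drift toward a weaker inhibitor, and within the usual scatter. Compound 3 is therefore expected at 1100 nM, with a range of 400 nM to 4000 nM.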

Compound 3, half-maximal inhibitory concentration: 8690 nM
Compound 3: the middle estimate sits 7.9-fold (0.90 log units) below what was measured; measured number above the stated range.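

Swapping bromo for methyl on the aromatic carbon exchanges one heavy atom for one heavy atom, with no change in rings, hydrogen-bond donors, hydrogen-bond acceptors or net charge, yet this assay shows a 12-fold higher number from compound 1 to compound 3 (1.06 log units; beyond the scatter). This position therefore responds strongly to a single-atom change, and methyl does not stand in for bromo on this core. Nothing measured among the compounds shown accounts for the size of this step.

On these data alone, it remains open whether chloro, methoxy or an amine at the same position would stay nearer compound 1 or nearer compound 3.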